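The source may report more compounds than this note shows. Statements on the series, on what has been measured and on what is new or still open speak of the compounds shown alone.

Measured so far in a physicochemical assay for acid dissociation:
compound 1, `Cc1cc(C)cc(Cc2ccc3c(NCCCNCc4ccco4)ccnc3c2)c1`, gives 9.47
compound 2, `c1coc(CNCCCNc2ccnc3cc(-c4cccc5ccccc45)ccc23)c1`, gives 9.47
compound 3, `c1coc(CNCCCNc2ccnc3cc(C4CCCCC4)ccc23)c1`, gives 9.47

Compound 3 stands level with compounds 1 and 2 at the digits given. The step of no change at the digits printed from compound 1 to compound 3 (within the scatter) and the step of no change at the digits printed from compound 2 to compound 3 (within the scatter) both lie within the scatter, as does the step of no change at the digits printed from compound 1 to compound 2 (within the scatter). Across the three measured compounds, then, changing the group on this aromatic carbon has left this assay untouched.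

Compound 4, `c1ccc(Cc2ccc3c(NCCCNCc4ccco4)ccnc3c2)cc1`, is not yet measured. It differs from compound 3 in one place: benzyl in place of cyclohexyl on an aromatic carbon. The group that leaves is a six-membered non-aromatic ring of carbon only; the group that enters, benzyl, carries a six-membered aromatic ring of carbon only; the place is on an aromatic carbon of a fused system of two rings, meta to a fused ring and para to a fused ring.

All three measured steps bear on this change, since each exchanges the group at the same aromatic carbon, and none moved this assay beyond the scatter. Benzyl also sits near 3,5-dimethylbenzyl of compound 1 in kind. No step beyond the scatter is therefore expected, so compound 4 is expected to give a step of no change at the digits printed from compound 3 to compound 4 (within the scatter). The estimate for compound 4 is 9.47, with a range from 9.2 to 9.75.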

Compound 4, acid dissociation constant: 9.47
For compound 4 middle estimate and measured number coincide at the digits printed; measured number inside the range.
By their numbers in this assay, from the lowest: compounds 1, 2, 3 and 4 (each within the scatter of the next).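

In this assay, benzyl in place of cyclohexyl on an aromatic carbon gives no change at the digits printed from compound 3 to compound 4 (within the scatter), so this position now has a group with a six-membered aromatic ring of carbon only alongside one with a six-membered non-aromatic ring of carbon only, with no step beyond the scatter between them. Benzyl in place of naphthalen-1-yl gives no change at the digits printed from compound 2 to compound 4 (within the scatter), while phenyl in place of 3,5-dimethylphenyl on a saturated chain carbon gives no change at the digits printed from compound 1 to compound 4 (within the scatter), which is the first change in the series made within a group rather than by exchanging the whole group. The absence of any step beyond the scatter therefore extends to all four compounds, with none going against it, and it covers the loss of the two methyl groups as well as the exchange of entire groups.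

What an amine or a carboxylic acid on this aromatic carbon would do to the reading remains open, since every group shown here is built of carbon and hydrogen alone. No measurement at hand accounts for the identical readings.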